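The compounds below may be only part of what the source reports. "The series", "measured", "known", "first", "only" and "open" are said of these compounds alone.

Compound 1 `N#CC1=C(N)N(c2ccc(S(N)(=O)=O)cc2)C2=C(C(=O)CCC2)C1/C=C/c1ccccc1` holds the highest of the three numbers shown in a functional assay on Ehrlich cells (Mus musculus) for antiproliferative activity, read by trypan blue exclusion, with a stated time of 2 h, tested at 25 ug/mL (a lower number here means a weaker effect, a higher number a stronger effect of the compound at the concentration tested), where compound 1 gives 10%; yet each step away from it stays within the scatter. Its nearest neighbour, compound 2 `COc1ccccc1C1C(C#N)=C(N)N(c2ccc(S(N)(=O)=O)cc2)C2=C1C(=O)CCC2`, gives 0%, and the furthest, compound 3 `N#CC1=C(N)N(c2ccc(S(N)(=O)=O)cc2)C2=C(C(=O)CCC2)C1c1c(O)ccc2ccccc12`, gives 0%. The step of a number 10 percentage points lower from compound 1 to compound 2 (within the scatter) and the step of a number 10 percentage points lower from compound 1 to compound 3 (within the scatter) are both within the scatter, and the step of no change at the digits printed from compound 2 to compound 3 (within the scatter) likewise.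

Compound 4 `COc1ccc(C2C(C#N)=C(N)N(c3ccc(S(N)(=O)=O)cc3)C3=C2C(=O)CCC3)c2ccccc12` is not yet measured in this assay. It differs from compound 1 by 4-methoxynaphthalen-1-yl in place of 2-phenylethenyl on a saturated ring carbon. The two measured steps that bear on it are those in which an aromatic group, 2-methoxyphenyl or 2-hydroxynaphthalen-1-yl, replaced 2-phenylethenyl on the same saturated ring carbon, and neither moved the number beyond the scatter. Compound 4 is therefore expected to give 2%, with a range from 0% to 15%. The estimated step of a number 8 percentage points lower from compound 1 to compound 4 (within the scatter) is expected to lie within the scatter, with no direction that can be trusted.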

Compound 4, a percentage reported as activity, at one concentration (the size of the read-out at that concentration, not a potency): 10%
For compound 4 the middle estimate is 8 percentage points below the measured one, and the stated range covers the measured number.
By their numbers in this assay, from the lowest: compounds 2, 3, 1 and 4 (each within the scatter of the next).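

With 4-methoxynaphthalen-1-yl in place of 2-phenylethenyl on the saturated ring carbon, this assay shows no change at the digits printed from compound 1 to compound 4 (within the scatter), so at this position a group without a double bond outside aromatic rings can give the same printed number as compound 1. Moving among the aromatic groups gives a number 10 percentage points higher from compound 3 to compound 4 (within the scatter) and a number 10 percentage points higher from compound 2 to compound 4 (within the scatter), so neither the methoxy-bearing naphthalene against the hydroxy-bearing one nor the naphthalene against the 2-methoxyphenyl group separates these compounds. No measurement at hand offers an explanation for these numbers.

On these data alone, it remains open whether an amine, a carboxylic acid or a longer alkyl chain on this carbon would move the number beyond the scatter. Also open, as far as these compounds go, is whether any of the four compounds would separate at another concentration or exposure time.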